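The source may report more compounds than this note shows. Statements on the series, on what has been measured and on what is new or still open speak of the compounds shown alone.

Measured compounds:
- Compound 1, `O=C1OC(C(O)Cn2cc(F)c(=O)[nH]c2=O)C(OCc2ccccc2)=C1OCc1ccccc1` — in an ADME assay on L1210/0 cells (Mus musculus) for cytotoxicity, with a stated time of 48 h (a higher number here means a weaker inhibitor, a lower number a stronger inhibitor), compound 1 gives 140000 nM.
- Compound 2, `O=C1OC(C(O)Cn2ccc(=O)[nH]c2=O)C(OCc2ccccc2)=C1OCc1ccccc1` — in this assay compound 2 gives 157000 nM.
- Compound 3, `C[C@@]1(CO)O[C@H](c2cc(F)c(N)cc2F)C[C@@H]1O` — in this assay compound 3 gives only a limit, > 200000 nM.

Compound 1 and compound 2 share one core and differ in a single place: hydrogen in place of fluoro on an aromatic carbon. The step this change made in this assay is a 1.1-fold higher number from compound 1 to compound 2 (0.05 log units; within the scatter), so the two values cannot be told apart. Compound 3 belongs to a different core; the difference between the two cores is not broken down here. The value of compound 3 is a limit of this assay rather than a number, (the limit of > 200000 nM in this assay, at which 1 of the 3 values shown sits).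

Compound 4, `C[C@@]1(CO)O[C@H](c2ccc(N)cc2F)C[C@@H]1O`, has not yet been measured. It comes from compound 3 by hydrogen in place of fluoro on an aromatic carbon. This is the same kind of change as that from compound 1 to compound 2, but the surroundings differ: in compound 1 the fluoro sits on a six-membered aromatic ring with two nitrogen, two atoms from the ring nitrogen and meta to a large group, whereas in compound 3 it sits on a six-membered aromatic ring of carbon only, ortho to an amino group and para to a fluoro group.

Given that the only measured instance of this change, a 1.1-fold higher number from compound 1 to compound 2 (0.05 log units; within the scatter), stayed within the scatter, compound 4 is expected to move by about a step that the limit leaves unreadable from compound 3 to compound 4. Compound 4 is therefore estimated at 250000 nM, most likely again reported as a limit, with a range from 120000 nM to 500000 nM.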

Compound 4, half-maximal inhibitory concentration: > 200000 nM
Compound 4: only a limit was reported; the forecaster's own chance of this, stated with the estimate: 80%; the middle value lies beyond the limit too.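

In this assay, compound 3 and compound 4 each give only a limit rather than a number, so no step between them can be read: the limit of > 200000 nM in this assay, at which 2 of the 4 values shown sit.

The compounds shown leave open whether hydrogen in place of fluoro on the core of compound 3 changes the read-out at all, and how far the true values of compound 3 and compound 4 lie beyond that limit.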